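The source may report more compounds than this note shows. Statements on the series, on what has been measured and on what is new or still open speak of the compounds shown alone.

Measured compounds:
Compound 1, `C[C@@H]1CN(c2sc(C(F)(F)F)nc2-c2nc3ccccc3[nH]2)CCN1C(=O)Cn1cc(Cl)cn1`: 1.7 nM
Compound 2, `Cc1nc(C)n(CC(=O)N2CCN(c3sc(C(F)(F)F)nc3-c3nc4cccc(C)c4[nH]3)C[C@H]2C)n1`: 3.1 nM
Compound 3, `C[C@@H]1CN(c2sc(C(F)(F)F)nc2-c2nc3ccccc3n2C)CCN1C(=O)Cn1cccn1`: 110 nM

In a functional assay on CHO-K1 cells for antagonist activity at C-X-C chemokine receptor type 3 (Homo sapiens), read by FLIPR, with a stated time of 10 min, in the presence of a further agent that is not named here (on this read-out higher numbers stand for weaker inhibition and lower numbers for stronger inhibition), compound 1 stands at the lowest of the three numbers. Compound 2 sits close to it, within the usual scatter of repeated measurements, so no order between compound 1 and compound 2 can be read from these two values. Compound 3 lies far above both, well beyond the scatter.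

Compound 4, `C[C@@H]1CN(c2sc(C(F)(F)F)nc2-c2nc3ccccc3[nH]2)CCN1C(=O)CN1C(=O)OC[C@@H]1c1ccccc1`, is not yet measured. It departs from compound 1 in a single place: 2-oxo-4-phenyl-1,3-oxazolidin-3-yl in place of 4-chloro-1H-pyrazol-1-yl on a saturated chain carbon bound to a carbonyl carbon. For the measured compounds named here, no pair of measured compounds isolates a change at the saturated chain carbon bound to the carbonyl carbon, so the weight of this position is unknown from the measured set. The entering group is larger than the leaving group and carries a defined stereocentre, which makes the outcome hard to anticipate from compound 1 alone. The step from compound 1 to compound 4 is expected to be a modest rise in the number, a 4.7-fold higher number from compound 1 to compound 4 (0.67 log units; beyond the scatter), a little beyond the scatter. For compound 4 the estimate is 8 nM, with a range from 2 nM to 40 nM.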

Compound 4, half-maximal inhibitory concentration: 360 nM
The estimate for compound 4 lay 45-fold (1.65 log units) below the measured number; the measured number lies above the stated range.
By their numbers in this assay, from the lowest: compounds 1 and 2 (each within the scatter of the next); then compound 3; then compound 4.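

In this assay, for the compounds shown here, the saturated chain carbon bound to a carbonyl carbon, whose weight the earlier compounds could not show, proves to be a sensitive position: 2-oxo-4-phenyl-1,3-oxazolidin-3-yl in place of 4-chloro-1H-pyrazol-1-yl gives a 210-fold higher number from compound 1 to compound 4 (2.33 log units; beyond the scatter). The shared core therefore does not hold the number low by itself, since this single exchange is enough to produce a large step. No measurement at hand accounts for the step, and it cannot be assigned to the phenyl ring, the defined stereocentre, the non-aromatic ring or the larger heavy-atom count.

The compounds shown leave open whether an unsubstituted 2-oxo-1,3-oxazolidin-3-yl group would behave like the entering group or stay closer to 4-chloro-1H-pyrazol-1-yl. Also open, on these data alone, is how the opposite configuration at the stereocentre, or a simple phenyl group on the chain carbon, would read.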